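Halogen swap on an indoleamine 2,3-dioxygenase 1 inhibitor series

A few compounds are considered here, and "the series" means these few. Any claim that something is new, unique, unknown or untested is made for them only; others in the source may bear on it.

Measured compounds:
compound 1, `O/N=C(/Nc1ccc(F)c(Cl)c1)c1ccc2occc2c1`: 1800 nM
compound 2, `O/N=C(/Nc1ccc(F)c(Br)c1)c1ccc2occc2c1`: 2600 nM
compound 3, `O/N=C(/Nc1cccc(Cl)c1)c1ccc2oc(COCC3CC3)cc2c1`: 17600 nM

All three were tested in an assay on tissue (HeLa cells) for inhibition of Indoleamine 2,3-dioxygenase 1 (Homo sapiens), read by spectrophotometry; on this read-out higher numbers stand for weaker inhibition and lower numbers for stronger inhibition. Compound 1 and compound 2 differ only by bromo in place of chloro on an aromatic carbon, and this gave a 1.4-fold higher number from compound 1 to compound 2 (0.16 log units; within the scatter). Compound 3 carries a different core; the difference between the core of compound 1 and the core of compound 3 is not broken down here, but in this assay compound 3 gives 17600 nM, the highest of the three numbers.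

Compound 4, `O/N=C(/Nc1cccc(Br)c1)c1ccc2oc(COCC3CC3)cc2c1`, has not yet been measured. It differs from compound 3 by bromo in place of chloro on an aromatic carbon. For the measured compounds named here, this is the same kind of change as the one from compound 1 to compound 2, but the surroundings differ: in compound 1 the exchanged halogen sits ortho to a fluoro group, while in compound 3 it does not. Since the earlier swap stayed within the scatter, a similarly small step is expected here, a 1.4-fold higher number from compound 3 to compound 4 (0.13 log units; within the scatter). On that basis compound 4 is estimated to give 24000 nM, with a likely range from 12000 nM to 50000 nM.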

Compound 4, half-maximal inhibitory concentration: 3200 nM
Compound 4: the middle estimate sits 7.5-fold (0.88 log units) above what was measured, and the stated range ends above it.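

In this assay, bromo in place of chloro gave a 5.5-fold lower number from compound 3 to compound 4 (0.74 log units; beyond the scatter), so on the core of compound 3 this swap moved the number clearly, whereas on the core of compound 1 it stayed within the scatter. The change therefore cannot be carried from one core to the other as a fixed step, as the two results disagree: the same change on two cores in this assay, a 1.4-fold higher number (0.16 log units; within the scatter) from compound 1 to compound 2 and a 5.5-fold lower number (0.74 log units; beyond the scatter) from compound 3 to compound 4, 7.9-fold (0.90 log units) apart, beyond the scatter of two such steps

This does not show what sets the two steps apart: the pairs differ in more than one place, including the fluoro group carried by compound 1 and compound 2, and a single pair on each core cannot separate these differences.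

The compounds shown leave open whether the fluoro group alone accounts for the gap between the two steps, or whether the rest of the core matters. They also leave open how other groups on the same aromatic carbon, such as iodo, methyl or an amine, would behave on either core.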